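The source may hold more compounds than are shown below. What is called first, only, known or untested is meant among the compounds shown, and "the series" means these compounds.

In an assay on NIH3T3 cells with Urotensin-2 receptor (Homo sapiens) as the target (a higher number here means that more compound is needed for the effect, a lower number that less compound is needed), compound 1 `CN(C)CCC(OC(=O)c1cn(C)c2ccccc12)c1ccc(Cl)cc1` gives 1510 nM. Going by the values given here, compound 2 `COc1ccc(C(=O)OC(CCN(C)C)c2ccc(Cl)cc2)cc1` gives 2190 nM in this assay, which is the higher of the two numbers measured so far, yet the gap to compound 1 lies within the scatter of repeated measurements, so the two compounds cannot be ranked against each other on this evidence. Compound 3 `Cc1cc(Br)ccc1C(=O)OC(CCN(C)C)c1ccc(Cl)cc1` has not yet been measured. It differs from compound 2 in one place: 4-bromo-2-methylphenyl in place of 4-methoxyphenyl on a carbonyl carbon. Among the compounds with values here, no pair of measured compounds that differ in a single spot is available, so there is no measured step to lean on; the two numbers in hand show only that exchanging the whole ring on the carbonyl carbon leaves the read-out in the same region. On that basis the expected outcome is a 1.2-fold lower number from compound 2 to compound 3 (0.09 log units; within the scatter), a move no larger than the scatter and in no firm direction. Compound 3 is therefore estimated to give 1800 nM in this assay, with a plausible range from 600 nM to 5500 nM.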

Compound 3, half-maximal effective concentration: 1070 nM
Estimate against measurement, compound 3: 1.7-fold (0.23 log units) above, within the range that was stated.
By their numbers in this assay, from the lowest: compounds 3, 1 and 2 (each within the scatter of the next, the first and the last beyond it).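

In this assay, the ring on the carbonyl carbon turns out to be a place where a single change can shift the read-out: 4-bromo-2-methylphenyl in place of 4-methoxyphenyl gives a 2.0-fold lower number from compound 2 to compound 3 (0.31 log units; beyond the scatter), a modest step but the first one in this set that can be read as a single-place change. The two groups have the same count of 8 heavy atoms, and the entering group has 0 hydrogen-bond acceptors where the leaving group has 1, so a hydrogen-bond acceptor on this ring is not required for a number in this region. No supporting data bear on why the step occurs.

The step swaps the methoxy group for a bromine and a methyl in one move, and the compounds shown do not separate what each of these contributes. Also open, going by these compounds, is how the read-out would respond to a quite different group on this ring, such as an amine, a nitrile or a carboxylic acid.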